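A few compounds are considered here, and "the series" means these few. Any claim that something is new, unique, unknown or untested is made for them only; others in the source may bear on it.

Measured so far:
- compound 1, `CC(/C=C/CC(C)CCCC(C)C)=C\C(=O)OCC(C)C`: 7.69
- compound 2, `COC(CCC(C)C/C=C/C(C)=C/C(=O)OC(C)C)C(C)C`: 5.95

Of the compounds shown here, two have been measured in a physicochemical assay for lipophilicity; on this read-out lower numbers stand for lower lipophilicity and higher numbers for higher lipophilicity. Compound 1 gives 7.69, the higher of the two numbers. Compound 2, a related ester, gives 5.95, a value well beyond the scatter below that of compound 1. Among the measured compounds shown here, no pair that differs in a single place has been measured, so there is no directly comparable step to lean on.

Compound 3, `CCNC(=O)/C=C(C)/C=C/CC(C)CCCC(C)C`, has not yet been measured in this assay. It differs from compound 1 in one place: ethylamino in place of isobutoxy on a carbonyl carbon. An isobutoxy group on a carbonyl carbon is exchanged for ethylamino on that carbonyl carbon.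

For this kind of change, a marked fall in this assay is expected, well beyond the scatter, so the expected step of a number 2.19 log units lower from compound 1 to compound 3 (beyond the scatter) points downward. Compound 3 is therefore expected to come in near 5.5, with a plausible range from 4.8 to 6.3.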

Compound 3, partition coefficient: 5.24
Compound 3: the middle estimate sits 0.26 log units above what was measured; the measured number falls inside the stated range.
By their numbers in this assay, from the lowest: compound 3; then compound 2; then compound 1.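

Among the compounds shown here, this is the first step at a single place: in this assay, ethylamino in place of isobutoxy on a carbonyl carbon gives a number 2.45 log units lower from compound 1 to compound 3 (beyond the scatter). With the rest of compound 1 unchanged, the large size of this step shows that the read-out depends strongly on the group at this carbonyl carbon. No measurement at hand explains the fall.

The change alters two things at once, replacing a group of 5 heavy atoms and no hydrogen-bond donor with one of 3 heavy atoms and 1 donor, so these compounds cannot show how much of the step goes with either difference. From the compounds shown here alone, how an isobutylamino group or a dimethylamino group on the same carbonyl carbon would read in this assay remains open, and either could help separate the two.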